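Cutting the fluorophenyl chain of compound 3 back to allyl

This account rests on a few compounds, and the source may have more. Where it says the series, first, only, none or still open, it means among the compounds named here.

Compound 3 (`O[C@@H](c1ccccc1)[C@H]1CO[C@H](c2ccccc2)[C@@H](C/C=C/c2cccc(F)c2)C1`) gives 8380 nM in a functional assay on HeLa cells (Homo sapiens) for cytotoxicity, read by WST assay, with a stated time of 48 h (on this read-out lower numbers stand for stronger inhibition and higher numbers for weaker inhibition), and sits within the scatter of compound 1 (`COc1ccc([C@H](O)[C@H]2CO[C@@H](c3ccc(OC)c(OC)c3)[C@H](C/C=C/c3ccccc3)C2)cc1OC`) at 16100 nM on the same read-out. Compound 2 (`COc1ccc(/C=C/C[C@@H]2C[C@@H]([C@@H](OC(C)=O)c3ccc(OC)c(OC)c3)CO[C@H]2c2ccc(OC)c(OC)c2)cc1OC`) returns only a limit (> 100000 nM) and no number. Compound 2 carries an aromatic ring at the end of its chain, so that ring alone does not guarantee a measurable number.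

Compound 4 (`C=CC[C@H]1C[C@@H]([C@@H](O)c2ccccc2)CO[C@@H]1c1ccccc1`) is not yet measured. The change from compound 3 is vinyl in place of 2-(3-fluorophenyl)ethenyl on a saturated chain carbon bound to a saturated ring carbon and cuts 3-(3-fluorophenyl)prop-2-en-1-yl back to allyl. For the measured compounds named here, no measured compound lacks the aromatic ring on this chain, so the series gives no direct reading of its loss.

The two numbers in hand, compound 1 at 16100 nM and compound 3 at 8380 nM in this assay on the same scale, both come from compounds that keep the ring, and this points to weaker inhibition once it goes. The expected size is a 4.2-fold higher number from compound 3 to compound 4 (0.62 log units; beyond the scatter) and such an estimated move would lie beyond the scatter. For compound 4 the expected value is 35000 nM with an estimated range from 12000 nM to 100000 nM and a limit reading also stays possible.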

Compound 4, half-maximal inhibitory concentration: 25400 nM
Compound 4: middle estimate off by 1.4-fold (0.14 log units), on the high side; the range from low to high includes it.
By their numbers in this assay, from the lowest: compounds 3, 1 and 4 (each within the scatter of the next, the first and the last beyond it). At a limit, above all of these: compound 2.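

In this assay, for the compounds shown here, the change to vinyl in place of 2-(3-fluorophenyl)ethenyl on a saturated chain carbon bound to a saturated ring carbon gives a 3.0-fold higher number from compound 3 to compound 4 (0.48 log units; beyond the scatter), the first direct reading of what the loss of the aromatic ring on this chain costs. The step is modest: compound 4 still returns a number, 25400 nM, rather than a limit, so in this pair the aromatic ring is not needed for a measurable value in this assay, although the compound that keeps it has the lower number. Nothing in the data at hand gives a cause for this step.

The change removes the aromatic ring and its fluorine together, and compound 1 differs from compound 3 in more than one place, so the share of the fluorine alone stays unread. Also open, as far as these compounds go, is how the number would respond at this position to a saturated propyl chain, a longer chain, or a chain ending in an amine or a carboxylic acid.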